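Ethoxy in Place of Methyl: A Small Step Expected

The source may hold more compounds than are shown below. What is called first, only, known or untested is meant among the compounds shown, and "the series" means these compounds.

Compound 1 `FC(F)(F)c1ccc(CSc2nc(Nc3ccccc3Cl)c3ccccc3n2)cc1` gives 20400 nM in a functional assay on PC-3 cells (Homo sapiens) for cytotoxicity, read by MTT assay, with a stated time of 72 h; on this read-out lower numbers stand for stronger inhibition and higher numbers for weaker inhibition.
Compound 2 `CCOc1ccccc1Nc1nc(SCc2ccc(C(F)(F)F)cc2)nc2ccccc12` gives 26200 nM in this assay.
Compound 3 `Cc1ccc(Nc2nc(SCc3ccc(C(F)(F)F)cc3)nc3ccccc23)cc1` gives 21100 nM in this assay.

All three measured compounds share the same core and differ only in the ring carried on the nitrogen. Compound 3 stands second highest of the three numbers, yet every gap between the three lies within the scatter, so no one of them can be called stronger or weaker than another. Replacing chloro with ethoxy came to a 1.3-fold higher number from compound 1 to compound 2 (0.11 log units; within the scatter); replacing 2-ethoxyphenyl with 4-methylphenyl came to a 1.2-fold lower number from compound 2 to compound 3 (0.09 log units; within the scatter); and replacing 2-chlorophenyl with 4-methylphenyl came to a 1.0-fold higher number from compound 1 to compound 3 (0.01 log units; within the scatter).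

Compound 4 `CCOc1ccc(Nc2nc(SCc3ccc(C(F)(F)F)cc3)nc3ccccc23)cc1` has not yet been measured. Against compound 3 the change is ethoxy in place of methyl on an aromatic carbon. Among the measured compounds shown here, two measured steps bear on it: an ethoxy group entering the same ring once before changed the number only within the scatter, and exchanging one substituted ring for another did the same. On this basis the expected step from compound 3 to compound 4 is one within the scatter, a 1.0-fold higher number from compound 3 to compound 4 (0.02 log units; within the scatter). Compound 4 is therefore estimated at 22000 nM, with a likely range from 10000 nM to 48000 nM.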

Compound 4, half-maximal inhibitory concentration: 32100 nM
Compound 4: the middle estimate sits 1.5-fold (0.16 log units) below what was measured; low and high end bracket the measured number.
By their numbers in this assay, from the lowest: compounds 1, 3, 2 and 4 (each within the scatter of the next).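

At this place on the ring, para to a large group, exchanging methyl for ethoxy adds a hydrogen-bond acceptor, yet in this assay the step stays within the scatter (a 1.5-fold higher number from compound 3 to compound 4 (0.18 log units; within the scatter)). Among the compounds shown here, the ethoxy group can also sit at either of the two ring positions seen here without a step beyond the scatter (a 1.2-fold higher number from compound 2 to compound 4 (0.09 log units; within the scatter)), and the same holds when 4-ethoxyphenyl takes the place of 2-chlorophenyl (a 1.6-fold higher number from compound 1 to compound 4 (0.20 log units; within the scatter)), so all four compounds remain indistinguishable in this assay, with no compound going against that reading. Nothing measured here offers an explanation for why these different rings give such close numbers.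

From the compounds shown here alone, what stays open is whether any group at this place can move the number beyond the scatter, for example a dimethylamino group, a carboxylic acid or a longer butoxy chain. The compounds shown also all keep the same trifluoromethyl-bearing arm on the shared core, so they say nothing about how much that part of the molecule contributes.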